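Swapping the benzyl group for a thiourea on the shared core

The source may hold more compounds than are shown below. What is called first, only, known or untested is meant among the compounds shown, and "the series" means these compounds.

Measured compounds:
Compound 1, `NC(=O)c1c(NC(=O)c2ccccc2Cl)sc2c1CCN(Cc1c(Cl)cccc1Cl)C2`: 4740 nM
Compound 2, `NC(=O)c1c(NC(=O)c2ccc(C(F)(F)F)cc2)sc2c1CCN(Cc1c(Cl)cccc1Cl)C2`: 8530 nM
Compound 3, `NC(=O)c1c(NC(=O)c2cccc([N+](=O)[O-])c2)sc2c1CCN(Cc1c(Cl)cccc1Cl)C2`: 13500 nM

In a functional assay on MKN-74 cells (Homo sapiens) for antiproliferative activity, with a stated time of 24 h (on this read-out lower numbers stand for stronger inhibition and higher numbers for weaker inhibition), compound 2 holds the second highest of the three numbers; compound 3 is nearest (a 1.6-fold higher number from compound 2 to compound 3 (0.20 log units; within the scatter)) and compound 1 furthest (a 1.8-fold higher number from compound 1 to compound 2 (0.26 log units; within the scatter)). Compound 4, `NC(=O)c1c(NC(=O)c2ccc(C(F)(F)F)cc2)sc2c1CCN(C(=S)Nc1ccccc1Cl)C2`, has not been measured. It differs from compound 2 as follows: a group of 10 heavy atoms (7 carbon, 1 nitrogen, 1 sulfur, 1 chlorine; one six-membered aromatic ring of carbon only) in place of a group of 9 heavy atoms (7 carbon, 2 chlorine; one six-membered aromatic ring of carbon only), on an amine nitrogen in a ring. The three measured steps all concern the group on the carbonyl carbon, not the group on the amine nitrogen in the ring, so none of them bears on this change. Going by the values given here, with no comparable step available, compound 4 is expected to stay close to compound 2, a 1.2-fold higher number from compound 2 to compound 4 (0.07 log units; within the scatter), with wide uncertainty. Compound 4 is therefore estimated at 10000 nM, within 3000 nM to 35000 nM.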

Compound 4, half-maximal inhibitory concentration: 16400 nM
The estimate for compound 4 lay 1.6-fold (0.21 log units) below the measured number; low and high end bracket the measured number.
By their numbers in this assay, from the lowest: compounds 1, 2, 3 and 4 (each within the scatter of the next, the first and the last beyond it).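

Compound 4 gives the first view of the amine nitrogen in a ring: in this assay, the thiourea in place of 2,6-dichlorobenzyl gives a 1.9-fold higher number from compound 2 to compound 4 (0.28 log units; within the scatter) and so does not separate the two compounds beyond the scatter. This holds even though the entering group carries a hydrogen-bond donor and a hydrogen-bond acceptor that 2,6-dichlorobenzyl lacks. No measurement at hand explains this result. Still open, from the compounds shown here alone, is what a carboxylic acid or a longer alkyl chain on this nitrogen would give. Also open, going by these compounds, is how the thiourea behaves alongside the 2-chlorophenyl of compound 1.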